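Expecting a Value for the Methoxy Compound

A few compounds are considered here, and "the series" means these few. Any claim that something is new, unique, unknown or untested is made for them only; others in the source may bear on it.

Measured so far in a functional assay on LNCaP cells (Homo sapiens) for antiproliferative activity; a higher number here means a weaker inhibitor, a lower number a stronger inhibitor:
- compound 1 `Cn1ncc(Cl)c1-c1cc(C(=O)N[C@@H]2CN[C@H](CCn3cncn3)C[C@H]2c2ccc(Cl)c(Cl)c2)oc1Cl`: 60 nM
- compound 2 `Cn1ncc(Cl)c1-c1cc(C(=O)N[C@@H]2CN[C@H](CCN3CCCCC3)C[C@H]2c2ccc(Cl)c(Cl)c2)oc1Cl`: 1780 nM
- compound 3 `CCC[C@@H]1C[C@@H](c2ccc(Cl)c(Cl)c2)[C@H](NC(=O)c2cc(-c3c(Cl)cnn3C)c(Cl)o2)CN1`: "not determined" (no result reported)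

Compound 3 has no number in this assay, so it offers no measured starting point. Compound 4 `COCC[C@@H]1C[C@@H](c2ccc(Cl)c(Cl)c2)[C@H](NC(=O)c2cc(-c3c(Cl)cnn3C)c(Cl)o2)CN1` differs from it by one change: methoxy in place of methyl on a saturated chain carbon, two bonds along the chain from a saturated ring carbon. In words, this is methoxy in place of methyl on a saturated chain carbon, two bonds along the chain from a saturated ring carbon, which turns propyl into 2-methoxyethyl.

Among the measured compounds shown here, the only measured step at this place is a 30-fold higher number from compound 1 to compound 2 (1.47 log units; beyond the scatter), a large step beyond the scatter, with piperidin-1-yl in place of 1H-1,2,4-triazol-1-yl. For the measured compounds named here, it shows that the read-out can move strongly with the group at this place, but neither group is the one in compound 3 or compound 4. With no value for compound 3, no size or direction of step can be expected in this assay. The estimate therefore leans on the two measured neighbours, compound 1 at 60 nM and compound 2 at 1780 nM. For compound 4 the expected value is 250 nM, with an estimated range of 60 nM to 1200 nM.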

Compound 4, half-maximal inhibitory concentration: 250 nM
Compound 4: the middle estimate sits on the measured number at the digits printed, within the range that was stated.
By their numbers in this assay, from the lowest: compound 1; then compound 4; then compound 2.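

In this assay, methoxy in place of piperidin-1-yl gives a 7.1-fold lower number from compound 2 to compound 4 (0.85 log units; beyond the scatter), while methoxy in place of 1H-1,2,4-triazol-1-yl gives a 4.2-fold higher number from compound 1 to compound 4 (0.62 log units; beyond the scatter). The position therefore now has three measured groups, and the open-chain 2-methoxyethyl of compound 4, which carries no ring at its end, falls between the two ring-ended chains of compound 1 and compound 2, so a ring at the chain end is not needed for a value in this span. From the compounds shown here alone, the step from compound 3 to compound 4 cannot be read, so the effect of methoxy in place of methyl stays unknown.

No measurement shown here explains this order. Still open, going by these compounds, is where a hydroxyl or a dimethylamino group at the end of the same chain would fall.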